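This account rests on a few compounds, and the source may have more. Where it says the series, first, only, none or still open, it means among the compounds named here.

Of the compounds shown here, three that share one core have been measured in an assay on isolated protein for inhibition of high affinity 3',5'-cyclic-AMP phosphodiesterase 7A (Homo sapiens), read by cAMP accumulation, with a stated time of 10 min; on this read-out higher numbers stand for weaker inhibition and lower numbers for stronger inhibition. Compound 1 `COc1nc2c(c(=O)n(C)c(=O)n2C)n1CC(=O)Nc1ccc(C(C)C)cc1` carries a 4-isopropylphenyl group on an amide-type nitrogen; in this assay compound 1 gives > 200000 nM, which is a limit of the measurement and not a number. Compound 2 `COc1nc2c(c(=O)n(C)c(=O)n2C)n1CC(=O)NCc1ccccc1Cl` carries a 2-chlorobenzyl group in that place instead, and in this assay compound 2 gives > 200000 nM, again only a limit. The change from compound 1 to compound 2 is therefore a step that the two limits leave unreadable from compound 1 to compound 2. Compound 3 `COc1nc2c(c(=O)n(C)c(=O)n2C)n1CCCC(=O)Nc1ccc(Cl)cc1` has a longer link between the core and the amide and a 4-chlorophenyl group; in this assay compound 3 gives > 200000 nM, once more a limit. So compound 3 stands at the limit of > 200000 nM in this assay, at which 3 of the 3 values shown sit, and no order among the three compounds can be read from these numbers.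

Compound 4 `COc1nc2c(c(=O)n(C)c(=O)n2C)n1CCCC(=O)Nc1ccc(C(C)C)cc1` keeps the longer link of compound 3 and differs from it only by isopropyl in place of chloro on an aromatic carbon. Among the measured compounds shown here, no measured step reads on this change, since the single step from compound 1 to compound 2 is itself unreadable. Compound 1 already bears the isopropyl group and in this assay gives > 200000 nM, a limit. The step from compound 3 to compound 4 is therefore expected to be a step that the limit leaves unreadable from compound 3 to compound 4, nothing beyond the scatter. The estimate for compound 4 in this assay is 300000 nM, between 100000 nM and 1000000 nM, most probably reported only as a limit.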

Compound 4, half-maximal inhibitory concentration: > 200000 nM
Compound 4: a limit, no number; the forecaster's own chance of this, stated with the estimate: 85%; the middle value lies beyond the limit too.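

In this assay compound 4 gives > 200000 nM, a limit and not a number, so no new step can be read from the change of compound 3 into compound 4. Whether swapping chloro for isopropyl, or any other change on the shared core, alters inhibition at all stays open, as no compound shown yields a number: the limit of > 200000 nM in this assay, at which 4 of the 4 values shown sit.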